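From hydroxy to methoxy on a phenyl ring

The source may hold more compounds than are shown below. What is called first, only, known or untested is meant among the compounds shown, and "the series" means these compounds.

Compound 1 `O=C(NCCCNc1cc(-c2cn(-c3ccccc3)nc2-c2cccc(O)c2)ccn1)Nc1ccc(F)cc1`: 970 nM
Compound 2 `O=C(NCCCNc1cc(-c2cn(-c3ccccc3)nc2-c2cccc(O)c2)ccn1)Nc1cccc(C(F)(F)F)c1`: 1080 nM

In a functional assay on RXF 393 cells (Homo sapiens) for antiproliferative activity, read by sulforhodamine B assay, with a stated time of 48 h (on this read-out higher numbers stand for weaker inhibition and lower numbers for stronger inhibition), compound 1 gives 970 nM. Among the measured compounds shown here, it has only one measured neighbour, and the two cannot be told apart: a 1.1-fold higher number from compound 1 to compound 2 (0.05 log units; within the scatter). That step swaps the aryl group on an amide-type nitrogen, so it leaves the hydroxy group untouched.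

Compound 3 `COc1cccc(-c2nn(-c3ccccc3)cc2-c2ccnc(NCCCNC(=O)Nc3ccc(F)cc3)c2)c1` keeps the rest of compound 1 and changes one spot: methyl in place of hydrogen on an oxygen on an aromatic ring. This is methyl in place of hydrogen on an oxygen on an aromatic ring, turning 3-hydroxyphenyl into 3-methoxyphenyl.

For the measured compounds named here, no measured step touches this oxygen, so the data give no direct guide to its effect. Going by the values given here, the one step available, a 1.1-fold higher number from compound 1 to compound 2 (0.05 log units; within the scatter), shows only that a change elsewhere left the number within the scatter. A step clearly beyond the scatter is therefore not expected in this assay, though a slight lean toward a higher number, meaning weaker inhibition, seems likely. The estimated change is a 1.5-fold higher number from compound 1 to compound 3 (0.19 log units; within the scatter). For compound 3 the expected value is 1500 nM, with an estimated range of 600 nM to 4500 nM.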

Compound 3, half-maximal inhibitory concentration: 6020 nM
For compound 3 the middle estimate is 4.0-fold (0.60 log units) below the measured one; measured number above the stated range.
By their numbers in this assay, from the lowest: compounds 1 and 2 (each within the scatter of the next); then compound 3.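

In this assay the oxygen on the aromatic ring proves to be a sensitive spot: putting methyl in place of its hydrogen gives a 6.2-fold higher number from compound 1 to compound 3 (0.79 log units; beyond the scatter) and so means clearly weaker inhibition. Among the compounds shown here, the only earlier step, a 1.1-fold higher number from compound 1 to compound 2 (0.05 log units; within the scatter) for a new aryl group on an amide-type nitrogen, could not show this, as it left the hydroxy group untouched and moved the number by no more than the usual scatter. Among the compounds shown, therefore, adding one carbon at this oxygen matters more than that aryl swap, though nothing here gives a measured reason for the loss.

As far as these compounds go, it remains open whether other groups in place of the hydrogen on this oxygen, such as ethyl or a longer chain, or an amine in place of the hydroxy group, would give numbers nearer compound 1 or compound 3. Also open, from the compounds shown here alone, is whether the same change from hydroxy to methoxy would weaken inhibition to a similar extent with 3-(trifluoromethyl)phenyl on the amide-type nitrogen, as in compound 2.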